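This account rests on a few compounds, and the source may have more. Where it says the series, first, only, none or still open, it means among the compounds named here.

Compound 1 `COc1ccccc1NC(=O)SC[C@H](NC(C)=O)C(=O)O`: in a functional assay on GC3/C1 cells (Homo sapiens) for cytotoxicity, read by MTT assay, with a stated time of 6 days (a higher number here means a weaker inhibitor, a lower number a stronger inhibitor), compound 1 gives > 200000 nM, which is a limit of the assay rather than a number.
Compound 2 `CC(=O)N[C@@H](CSC(=O)Nc1ccc(Cl)cc1)C(=O)O`: in this assay compound 2 gives 8130 nM.
Compound 3 `CC(=O)N[C@@H](CSC(=O)Nc1ccccc1)C(=O)O`: in this assay compound 3 gives 178000 nM.

Compound 3 holds the highest of the two numbers; its nearest neighbour is compound 2, separated by a 22-fold higher number from compound 2 to compound 3 (1.34 log units; beyond the scatter). Compound 4 `CC(=O)N[C@@H](CSC(=O)Nc1ccccc1Cl)C(=O)O` differs from compound 3 by chloro in place of hydrogen on an aromatic carbon. Among the compounds with values here, two measured steps bear on this change. The step of a 22-fold higher number from compound 2 to compound 3 (1.34 log units; beyond the scatter) shows that chloro on an aromatic carbon can bring a large lowering. The step of an at least 1.1-fold lower number from compound 1 to compound 3 (0.05 log units; that floor lies within the scatter) shows that methoxy on an aromatic carbon brought no gain at all. Compound 1 sits at the limit of > 200000 nM in this assay, at which 1 of the 3 values shown sits. Because an at least 1.1-fold lower number from compound 1 to compound 3 (0.05 log units; that floor lies within the scatter) shows that methoxy ortho to a large group brought no gain, and the chloro of compound 4 sits ortho to a large group as well, only part of the lowering seen in a 22-fold higher number from compound 2 to compound 3 (1.34 log units; beyond the scatter) is expected in this assay. The estimate for compound 4 is 60000 nM, with a range from 12000 nM to 200000 nM. That expected value corresponds to a 3.0-fold lower number from compound 3 to compound 4 (0.47 log units; beyond the scatter).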

Compound 4, half-maximal inhibitory concentration: > 200000 nM
Compound 4: no number, only a limit; the forecaster's own chance of this, stated with the estimate: 25%; middle value at least 3.3-fold (0.52 log units) from the limit.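

Compound 4 gives only a limit in this assay, not a number, and compound 1 gives one too: the limit of > 200000 nM in this assay, at which 2 of the 4 values shown sit. The step of an at least 1.1-fold higher number from compound 3 to compound 4 (0.05 log units; that floor lies within the scatter) shows no readable lowering from chloro ortho to a large group, unlike the chloro of compound 2. Methoxy and chloro in this place have now both shown no gain over hydrogen.

The step between compound 1 and compound 4 cannot be read, as both values are limits. Going by these compounds, whether an amine or a fluoro group in this place would lower the number remains open.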